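The source may hold more compounds than are shown below. What is called first, only, known or untested is meant among the compounds shown, and "the series" means these compounds.

The study turns on a single exchange made twice. Compound 1 `CCCCCCCCS(=O)(=O)Nc1cc(-c2ccccc2Cl)ccc1C(=O)O` and compound 2 `CCCCCCCCS(=O)(=O)Nc1cc(-c2ccccc2-c2ccccc2)ccc1C(=O)O` share one core, and in an assay on mitochondria (strain BALB/c) for inhibition of glycerol-3-phosphate acyltransferase 1, mitochondrial (Mus musculus), read by scintillation counting, with a stated time of 10 min (a higher number here means a weaker inhibitor, a lower number a stronger inhibitor), compound 1 gives 26900 nM while compound 2 gives 17100 nM. What separates them is phenyl in place of chloro on an aromatic carbon, and the step it made is a 1.6-fold lower number from compound 1 to compound 2 (0.20 log units; within the scatter).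

Compound 3 `CCCCCCCCS(=O)(=O)Nc1ccc(-c2ccccc2Cl)cc1C(=O)O` carries the same groups on a second core; the difference between the two cores is not broken down here. In this assay compound 3 gives 14400 nM, and its gaps to compound 2 and to compound 1 both lie within the scatter, so nothing firm can be read from a comparison of these three numbers.

Compound 4 `CCCCCCCCS(=O)(=O)Nc1ccc(-c2ccccc2-c2ccccc2)cc1C(=O)O` has not yet been measured. It differs from compound 3 by phenyl in place of chloro on an aromatic carbon, the same change as that made between compound 1 and compound 2, at a place described in the same words. Among the compounds with values here, the expectation for compound 4 rests on compound 1 and compound 2, because a 1.6-fold lower number from compound 1 to compound 2 (0.20 log units; within the scatter) is the only measured instance of this change, and that step stays within the scatter. The change is therefore expected to make a step of similar size, a 1.6-fold lower number from compound 3 to compound 4 (0.20 log units; within the scatter). Compound 4 is estimated at 9000 nM in this assay, with most repeats expected between 4500 nM and 18000 nM.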

Compound 4, half-maximal inhibitory concentration: 10100 nM
Compound 4: the middle estimate sits 1.1-fold (0.05 log units) below what was measured, and the stated range covers the measured number.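

In this assay, phenyl in place of chloro on an aromatic carbon gave a 1.4-fold lower number from compound 3 to compound 4 (0.15 log units; within the scatter), so on this second core the exchange again produced a step inside the scatter. Set beside the earlier step, the new one shows that the exchange behaved alike on the two cores, with no measurable difference in the size of the step: the same change on two cores in this assay, a 1.6-fold lower number (0.20 log units; within the scatter) from compound 1 to compound 2 and a 1.4-fold lower number (0.15 log units; within the scatter) from compound 3 to compound 4, 1.1-fold (0.04 log units) apart, within the scatter of two such steps. This agreement is consistent with the change carrying over between these two cores, but neither step stands clear of the scatter, so the pairs do not show that the exchange really moves the number on either core, and two pairs say nothing about a further core.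

The compounds shown hold only chloro or phenyl at this place, which leaves open whether a fluoro, a methoxy or a nitrile there would produce a step beyond the scatter, and whether such a step would also carry from one core to the other. As far as these compounds go, all four compounds also share one chain and one carboxylic acid, so the effect of a shorter chain, or of an amide in place of that acid, remains open as well.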